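The source may hold more compounds than are shown below. What is called first, only, known or untested is meant among the compounds shown, and "the series" means these compounds.

Measured compounds:
Compound 1, `Cc1cc(C(=O)Nc2ccccc2)nn1Cc1cc(Cl)ccc1OCc1ccccc1`, 39.8 nM
Compound 2, `Cc1cc(C(=O)NCc2ccccc2)nn1Cc1cc(Cl)ccc1OCc1ccccc1`, 39.8 nM
Compound 3, `Cc1cc(C(=O)NCc2cccnc2)nn1Cc1cc(Cl)ccc1OCc1ccccc1`, 50.1 nM

In an assay on CHO-K1 cells for displacement of a labelled ligand from prostaglandin E2 receptor EP1 subtype (Homo sapiens) (a lower number here means a stronger inhibitor, a higher number a weaker inhibitor), compound 1 gives 39.8 nM. It is level with compound 2, and together these two give the lowest numbers of the three; compound 3 gives 50.1 nM. The two measured steps away from compound 1 were small: no change at the digits printed from compound 1 to compound 2 (within the scatter), and a 1.3-fold higher number from compound 1 to compound 3 (0.10 log units; within the scatter). The step between the other two, a 1.3-fold higher number from compound 2 to compound 3 (0.10 log units; within the scatter), is of the same kind.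

Compound 4, `CC(=O)Nc1cc(C)n(Cc2cc(Cl)ccc2OCc2ccccc2)n1`, is not yet measured in this assay. It differs from compound 1 as follows: acetamido in place of phenylcarbamoyl on an aromatic carbon. Here the six-membered aromatic ring of carbon only leaves altogether, and a group of four heavy atoms enters in place of one of nine.

Within the data shown here, none of the measured steps bears directly on this change. All three vary only what sits on the amide-type nitrogen, and each stayed within the scatter, while the carbonyl and the aromatic ring were kept throughout. Among the measured compounds shown here, there is no measured compound without that ring, so the data give no anchor for its loss. The account therefore expects a step toward a higher number for compound 4, of uncertain size, a 10-fold higher number from compound 1 to compound 4 (1.00 log units; beyond the scatter).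

The estimate for compound 4 is 400 nM, with a range from 80 nM to 3000 nM.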

Compound 4, half-maximal inhibitory concentration: 316 nM
Compound 4: the middle estimate sits 1.3-fold (0.10 log units) above what was measured, within the range that was stated.
By their numbers in this assay, from the lowest: compounds 1, 2 and 3 (each within the scatter of the next); then compound 4.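

In this assay this position on the aromatic carbon, which showed no step beyond the scatter while phenyl, benzyl and (pyridin-3-yl)methyl were exchanged on the amide nitrogen, does respond once the group is cut back to acetamido (a 7.9-fold higher number from compound 1 to compound 4 (0.90 log units; beyond the scatter)), and the steps from the two other amides are of similar size (a 7.9-fold higher number from compound 2 to compound 4 (0.90 log units; beyond the scatter); a 6.3-fold higher number from compound 3 to compound 4 (0.80 log units; beyond the scatter)). The flat numbers among compounds 1, 2 and 3 therefore did not mean that anything could sit here: the three compounds that carry an aromatic ring on this group stand together, while compound 4, with no ring in it, stands apart. The same change also puts the amide nitrogen rather than the carbonyl carbon on the aromatic carbon, so the shares of the ring loss and of the turned amide cannot be separated, and no measurement at hand explains the step.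

The compounds shown leave open whether methylcarbamoyl, which keeps the amide the way round it stands in compound 1 but has no ring, would follow compound 1 or compound 4. They also leave open whether benzamido, which keeps the ring on the turned amide, or a longer chain such as hexanamido, would bring the number back toward that of compound 1.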